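The compounds below may be only part of what the source reports. "The series", "measured", "known", "first", "only" and "open" are said of these compounds alone.

Three close relatives share one core, differing only in the group that sits on a saturated ring carbon. Compound 1 `CCCCCCCCCCCCCCCCCCNC(=O)[C@H]1CSC(C2CCCCC2)N1` carries a cyclohexyl there, and in a functional assay on PPC-1 cells (Homo sapiens) for antiproliferative activity, read by sulforhodamine B assay (a lower number here means a stronger inhibitor, a higher number a weaker inhibitor), compound 1 gives 9300 nM. Compound 2 `CCCCCCCCCCCCCCCCCCNC(=O)[C@H]1CSC(Cc2ccccc2)N1` carries a benzyl instead, and in this assay compound 2 gives 4000 nM. Compound 3 `CCCCCCCCCCCCCCCCCCNC(=O)[C@H]1CSC(c2ccc(F)cc2)N1` carries a 4-fluorophenyl, and in this assay compound 3 gives 2100 nM. Among these three, compound 3 has the lowest number: the change a 4.4-fold lower number from compound 1 to compound 3 (0.65 log units; beyond the scatter) is clear, while the gap a 1.9-fold lower number from compound 2 to compound 3 (0.28 log units; within the scatter) is not resolved by this kind of measurement, and the swap a 2.3-fold lower number from compound 1 to compound 2 (0.37 log units; beyond the scatter) lies between the two.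

Compound 4 `CCCCCCCCCCCCCCCCCCNC(=O)[C@H]1CSC(c2cc(F)cc(F)c2)N1` is the next step. It differs from compound 3 in one place: 3,5-difluorophenyl in place of 4-fluorophenyl on a saturated ring carbon. For the measured compounds named here, no measured step here adds or moves a fluorine on an aromatic ring; the steps that exist replace whole groups on this carbon, and the nearest of them, from a benzyl to a 4-fluorophenyl, stayed within the scatter. The change to compound 4 is smaller than any of those, so a step in this assay of size a 1.1-fold lower number from compound 3 to compound 4 (0.02 log units; within the scatter) is expected, which is to say none beyond the scatter. Compound 4 is therefore estimated at 2000 nM, within a range from 900 nM to 4500 nM.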

Compound 4, half-maximal inhibitory concentration: 10600 nM
For compound 4 the middle estimate is 5.3-fold (0.72 log units) below the measured one, outside the stated range (above it).
By their numbers in this assay, from the lowest: compounds 3 and 2 (each within the scatter of the next); then compounds 1 and 4 (each within the scatter of the next).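

At this position, altering only the fluorines on the aromatic ring, with 3,5-difluorophenyl in place of 4-fluorophenyl, gives a 5.0-fold higher number from compound 3 to compound 4 (0.70 log units; beyond the scatter) in this assay, a step comparable in size to the whole-group swap a 4.4-fold lower number from compound 1 to compound 3 (0.65 log units; beyond the scatter) shown earlier. The aromatic ring alone therefore does not fix the number here: the replacement of benzyl gives a 2.7-fold higher number from compound 2 to compound 4 (0.42 log units; beyond the scatter), while the replacement of cyclohexyl gives a 1.1-fold higher number from compound 1 to compound 4 (0.06 log units; within the scatter), which leaves a fluorinated aromatic ring and a saturated one level in this assay. No measurement is available that explains why the fluorine pattern matters so much on this carbon.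

The compounds shown cannot separate the effect of adding a second fluorine from the effect of no longer having the 4-fluorophenyl pattern, and a plain phenyl would give a reference point for both. From the compounds shown here alone, it also remains open how this carbon would respond to an aromatic ring bearing a methoxy group, an amine or a carboxylic acid, and whether the same fluorine step would hold with a shorter chain on the amide.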